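The source may hold more compounds than are shown below. What is called first, only, known or untested is meant among the compounds shown, and "the series" means these compounds.

Measured so far in an ADME assay for permeability, using PAMPA, at pH 7.4; a lower number here means that the compound crosses the layer more slowly, a higher number that the compound crosses the layer faster:
compound 1 `Cc1cc(NC(=O)Nc2ccc(N)cc2)c2ccccc2n1` — 530 10^-6 cm/s
compound 2 `CC(=O)c1ccc(NC(=O)Nc2cc(C)nc3ccccc23)cc1` — 473 10^-6 cm/s
compound 3 `CSc1ccc(NC(=O)Nc2cc(C)nc3ccccc23)cc1` — 473 10^-6 cm/s

Compound 3 stands level with compound 2 at the digits shown, and its gap to compound 1, a 1.1-fold lower number from compound 1 to compound 3 (0.05 log units; within the scatter), is as small as a 1.1-fold lower number from compound 1 to compound 2 (0.05 log units; within the scatter) and no change at the digits printed from compound 2 to compound 3 (within the scatter): all three values sit within the scatter of one another. Compound 4 `CCc1ccc(NC(=O)Nc2cc(C)nc3ccccc23)cc1` carries ethyl in place of methylsulfanyl on an aromatic carbon. Going by the values given here, the steps that bear on this change are those that swap the group on the same aromatic carbon, and none of them moved the number beyond the scatter. Compound 4 is therefore expected to show a 1.0-fold lower number from compound 3 to compound 4 (0.00 log units; within the scatter), no shift beyond the scatter. The value of compound 4 is estimated at 470 10^-6 cm/s, with a range from 300 10^-6 cm/s to 700 10^-6 cm/s.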

Compound 4, apparent permeability: 535 10^-6 cm/s
Compound 4: middle estimate off by 1.1-fold (0.06 log units), on the low side; the measured number falls inside the stated range.
By their numbers in this assay, from the lowest: compounds 2, 3, 1 and 4 (each within the scatter of the next).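

Ethyl in place of methylsulfanyl gives a 1.1-fold higher number from compound 3 to compound 4 (0.05 log units; within the scatter) in this assay and so adds a group with no hydrogen-bond acceptor to those tried on this aromatic carbon, para to a large group. Ethyl also gives a 1.1-fold higher number from compound 2 to compound 4 (0.05 log units; within the scatter) against acetyl and a 1.0-fold higher number from compound 1 to compound 4 (0.00 log units; within the scatter) against amino, so all four groups at this position lie within the scatter of one another. Nothing available accounts for this evenness. From the compounds shown here alone, whether a carboxylic acid or a longer chain at this position would stay within that scatter remains open, as does the effect of any change to the shared core.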